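Compound 3: a methyl added to compound 2

This account rests on a few compounds, and the source may have more. Where it says the series, first, only, none or still open, it means among the compounds named here.

Compound 1 `COc1cc(Sc2c(C)[nH]c3ccccc23)cc(OC)c1OC` gives 46 nM
Compound 2 `COc1cc(Sc2c[nH]c3ccc(Cl)cc23)cc(OC)c1OC` gives 77 nM

In a functional assay on MCF7 cells (Homo sapiens) for inhibition, with a stated time of 48 h (a higher number here means a weaker inhibitor, a lower number a stronger inhibitor), compound 2 (77 nM) stands level with compound 1 (46 nM), and the two values lie within the usual scatter of each other. Compound 3 `COc1cc(Sc2c(C)[nH]c3ccc(Cl)cc23)cc(OC)c1OC` is still unmeasured. It departs from compound 2 by one change, (methyl in place of hydrogen on an aromatic carbon), with methyl in place of hydrogen on an aromatic carbon, next to the ring nitrogen. Going by the values given here, no measured pair shows this change directly, so the expectation in this assay rests only on compound 1 at 46 nM and compound 2 at 77 nM and is modest: no step beyond the scatter. The expected step is a 1.7-fold lower number from compound 2 to compound 3 (0.23 log units; within the scatter) as an estimate. For compound 3 the estimated value is 45 nM with an expected range from 14 nM to 140 nM in this test.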

Compound 3, half-maximal inhibitory concentration: 82 nM
For compound 3 the middle estimate is 1.8-fold (0.26 log units) below the measured one; the measured number falls inside the stated range.
By their numbers in this assay, from the lowest: compounds 1, 2 and 3 (each within the scatter of the next).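

In this assay, methyl in place of hydrogen on an aromatic carbon, next to the ring nitrogen, now has a direct reading: with the chloro present, it gives a 1.1-fold higher number from compound 2 to compound 3 (0.03 log units; within the scatter) and so shows no step beyond the scatter at this position. Going by these compounds alone, the same compound also gives the first direct reading of the chloro with the methyl present, as a 1.8-fold higher number from compound 1 to compound 3 (0.25 log units; within the scatter), so neither single change separates these compounds in this test. Nothing available explains why these steps stay within the scatter. The compounds shown leave open how a longer chain or an amine would read on this same carbon, and how the shared core reads with hydrogen at both places.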